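The source may report more compounds than this note shows. Statements on the series, on what has been measured and on what is new or still open speak of the compounds shown alone.

Measured compounds: compound 1 `OCCNc1nc(-c2ccccc2)nc2c1nnn2Cc1ccccc1` gives 38000000 nM in an assay on isolated protein for binding affinity to adenosine receptor A1 (Bos taurus); on this read-out lower numbers stand for stronger inhibition and higher numbers for weaker inhibition; compound 2 `CCCNc1nc(-c2ccccc2)nc2c1nnn2Cc1ccccc1` gives 37000000 nM; compound 3 `CCCCNc1nc(-c2ccccc2)nc2c1nnn2Cc1ccccc1` gives 11000000 nM.

Compound 3 holds the lowest number of the three, separated from both others by steps beyond the scatter. Compound 4 `CNc1nc(-c2ccccc2)nc2c1nnn2Cc1ccccc1` differs from it by hydrogen in place of propyl on a saturated chain carbon bound to a nitrogen on an aromatic ring. The step that bears on this is a 3.4-fold lower number from compound 2 to compound 3 (0.53 log units; beyond the scatter), where lengthening the chain lowered the number modestly, while a 1.0-fold lower number from compound 1 to compound 2 (0.01 log units; within the scatter) stayed within the scatter. Shortening the chain by three carbons is therefore expected to raise the number beyond the scatter, and compound 4 is estimated at 60000000 nM with a range of 15000000 nM to 250000000 nM, corresponding to a 5.5-fold higher number from compound 3 to compound 4 (0.74 log units; beyond the scatter).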

Compound 4, inhibition constant: 353000000 nM
Beside the measured number, compound 4's estimate is 5.9-fold (0.77 log units) below it, outside the stated range (above it).
By their numbers in this assay, from the lowest: compound 3; then compounds 2 and 1 (each within the scatter of the next); then compound 4.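

In this assay, going by these compounds alone, the butyl to methyl change at this position counts for far more than any step among the earlier compounds (a 32-fold higher number from compound 3 to compound 4 (1.51 log units; beyond the scatter)). Compound 4 also stands clear of the two compounds with intermediate chains (a 9.5-fold higher number from compound 2 to compound 4 (0.98 log units; beyond the scatter); a 9.3-fold higher number from compound 1 to compound 4 (0.97 log units; beyond the scatter)), so the hydroxy-bearing chain of compound 1 still keeps a lower number than the methylamino group. From the compounds shown here alone, whether a longer chain than butyl, or an amine or carboxylic acid at the chain end, would lower the number further remains open. No evidence at hand accounts for the size of this step.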